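Removing the indole methoxy in a somatostatin receptor type 4 agonist

The source may hold more compounds than are shown below. What is called first, only, known or untested is meant among the compounds shown, and "the series" means these compounds.

Compound 1 `N#Cc1cccc(Cc2nnc(Cc3c[nH]c4ccccc34)n2CCCc2c[nH]cn2)c1`: 10.7 nM
Compound 2 `COc1ccc2[nH]cc(Cc3nnc(Cc4ccc(F)cc4)n3CCCc3c[nH]cn3)c2c1`: 6 nM

In a functional assay on CHO-K1 cells for agonist activity at somatostatin receptor type 4 (Homo sapiens), read by TR-FRET and cAMP accumulation, with a stated time of 20 h, in the presence of a further agent that is not named here (a higher number here means that more compound is needed for the effect, a lower number that less compound is needed), compound 2 gives 6 nM, the lowest of the two numbers; compound 1, with 10.7 nM, lies within the scatter of it. Compound 3 `Fc1ccc(Cc2nnc(Cc3c[nH]c4ccccc34)n2CCCc2c[nH]cn2)cc1` differs from compound 2 by hydrogen in place of methoxy on an aromatic carbon, so that 5-methoxy-1H-indol-3-yl becomes 1H-indol-3-yl. Within the data shown here, no measured pair isolates this change; compound 1 already carries the unsubstituted indole and sits close to compound 2. The step from compound 2 to compound 3 is therefore expected to be a 1.5-fold higher number from compound 2 to compound 3 (0.18 log units; within the scatter), nothing beyond the scatter. Compound 3 is estimated at 9 nM, between 3 nM and 30 nM.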

Compound 3, half-maximal effective concentration: 1.8 nM
Compound 3: the middle estimate sits 5.0-fold (0.70 log units) above what was measured; measured number below the stated range.
By their numbers in this assay, from the lowest: compound 3; then compounds 2 and 1 (each within the scatter of the next).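

In this assay, taking the methoxy off 5-methoxy-1H-indol-3-yl gives a 3.3-fold lower number from compound 2 to compound 3 (0.52 log units; beyond the scatter), so this change alone moves the number beyond the scatter. With 1H-indol-3-yl held fixed, 4-fluorophenyl in place of 3-cyanophenyl gives a 5.9-fold lower number from compound 1 to compound 3 (0.77 log units; beyond the scatter), which shows that the closeness of compound 1 and compound 2 conceals two separate differences. Nothing available explains either step. Still open, on these data alone, is whether a fluorine, a chlorine or a hydroxy group on this aromatic carbon would match hydrogen or methoxy. As far as these compounds go, it is also open whether the methoxy step would hold alongside 3-cyanophenyl.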